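Dropping a Methoxy Group from Compound 3

The source may hold more compounds than are shown below. What is called first, only, known or untested is meant among the compounds shown, and "the series" means these compounds.

Compound 1 `COc1ccc(-c2cc(/C=C/C(=O)c3ccc(N)cc3)[nH]n2)cc1`: 95%
Compound 2 `COc1cc(-c2cc(/C=C/C(=O)c3ccc(Cl)c(Cl)c3)[nH]n2)cc(OC)c1OC`: 91%
Compound 3 `COc1ccc(C(=O)/C=C/c2cc(-c3cc(OC)c(OC)c(OC)c3)n[nH]2)cc1OC`: 97%

In a functional assay on CAKI-1 cells (Homo sapiens) for cytotoxicity, read by sulforhodamine B assay, with a stated time of 48 h, tested at 0.01 uM (on this read-out higher numbers stand for a weaker effect at the one concentration tested and lower numbers for a stronger effect), compound 3 gives the highest of the three numbers, yet its distance to compound 1 and to compound 2 lies within the scatter, so the three compounds cannot be ordered. Compound 4 `COc1ccc(C(=O)/C=C/c2cc(-c3cc(OC)c(OC)c(OC)c3)n[nH]2)cc1` differs from compound 3 in one place: hydrogen in place of methoxy on an aromatic carbon. Among the measured compounds shown here, the only measured step that touches the ring on the carbonyl carbon is a number 6 percentage points higher from compound 2 to compound 3 (within the scatter), itself within the scatter. Nothing measured here therefore points to a move beyond the scatter for compound 4, and its value in this assay is estimated at 95% (range 85% to 102%), which means an expected step of a number 2 percentage points lower from compound 3 to compound 4 (within the scatter).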

Compound 4, a percentage reported as activity, at one concentration (the size of the read-out at that concentration, not a potency): 95%
Compound 4: the middle estimate sits on the measured number at the digits printed; low and high end bracket the measured number.
By their numbers in this assay, from the lowest: compounds 2, 1, 4 and 3 (each within the scatter of the next).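

In this assay, hydrogen in place of methoxy on this aromatic carbon turns 3,4-dimethoxyphenyl into 4-methoxyphenyl and gives a number 2 percentage points lower from compound 3 to compound 4 (within the scatter), so this position shows no readable effect of the methoxy group at the one concentration tested. Exchanging the whole ring, with 4-methoxyphenyl in place of 3,4-dichlorophenyl on the carbonyl carbon, gives a number 4 percentage points higher from compound 2 to compound 4 (within the scatter), which also cannot be told from scatter. No evidence on hand bears on these results.

On these data alone, whether a hydroxy group, an amine or a fluorine atom at this position would give a step beyond the scatter remains open.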